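This account rests on a few compounds, and the source may have more. Where it says the series, first, only, none or still open, it means among the compounds named here.

Compound 1 `Cc1ccc2c(NCc3ccc(NC(=O)C4CCN(Cc5cccc(F)c5)CC4)cc3)nc(N(C)C)nc2c1`: in a functional assay on SV5A8 cells (Homo sapiens) for cytotoxicity (a lower number here means a stronger inhibitor, a higher number a weaker inhibitor), compound 1 gives > 4170 nM, a limit of the assay.
Compound 2 `Cc1ccc2c(NCc3ccc(NC(=O)C4CCN(Cc5ccccc5)CC4)cc3)nc(N3CCC3)nc2c1`: compound 2 gives > 8500 nM, a limit.
Compound 3 `Cc1ccc2c(NCc3ccc(NC(=O)C4CCN(Cc5ccccc5)CC4)cc3)nc(N3CCCC3)nc2c1`: compound 3 gives > 7790 nM, a limit.

Compound 1 stands at a limit in this assay, and the two other values shown are limits as well (the limit of > 4170 nM in this assay, at which 1 of the 3 values shown sits, (the limit of > 7790 nM in this assay, at which 1 of the 3 values shown sits), (the limit of > 8500 nM in this assay, at which 1 of the 3 values shown sits)). Compound 4 `Cc1ccc2c(NCc3ccc(NC(=O)C4CCN(CC(C)C)CC4)cc3)nc(N(C)C)nc2c1` differs from compound 1 by isopropyl in place of 3-fluorophenyl on a saturated chain carbon bound to an amine nitrogen in a ring. Going by the values given here, no measured step covers this change. Among the compounds with values here, the only measured step, a step that the two limits leave unreadable from compound 2 to compound 3, sits elsewhere on the shared core and is itself unreadable between two limits, so it yields neither size nor direction. With every value shown a limit, no step beyond the scatter can be expected. Compound 4 is estimated at 8000 nM, range 3000 nM to 30000 nM, most probably again reported only as a limit. The expected step that the limit leaves unreadable from compound 1 to compound 4 is therefore none beyond the scatter.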

Compound 4, half-maximal inhibitory concentration: > 10500 nM
Compound 4 was reported as a limit; the forecaster's own chance of this, stated with the estimate: 80%; middle value at least 1.3-fold (0.11 log units) from the limit.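

Compound 1 and compound 4 are both reported only as limits, so no step can be read between them. The compounds shown leave open whether the change from 3-fluorobenzyl to isobutyl shifts potency in this assay at all, and in which direction.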